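The source may report more compounds than this note shows. Statements on the series, on what has been measured and on what is new or still open speak of the compounds shown alone.

In a functional assay on MDA-MB-231 cells (Homo sapiens) for antiproliferative activity, with a stated time of 4 days (on this read-out lower numbers stand for stronger inhibition and higher numbers for weaker inhibition), compound 1 `COc1ccc(-c2[nH]c3ccccc3c2C=O)cc1` gives 470 nM and compound 2 `COc1ccc(-c2[nH]c3ccc(OC)cc3c2C=O)cc1` gives 260 nM. For the measured compounds named here, these are the only two numbers so far, and they lie within the scatter of each other. Compound 3 `COc1ccc(-c2[nH]c3cc(F)ccc3c2C=O)cc1` has not yet been measured. It differs from compound 1 by a single change, fluoro in place of hydrogen on an aromatic carbon of a six-membered aromatic ring of carbon only, part of a fused or bridged system of two rings. Going by the values given here, only one measured step offers any guide, and it introduces methoxy, not fluoro: a 1.8-fold lower number from compound 1 to compound 2 (0.26 log units; within the scatter). With that step inside the scatter, no step beyond the scatter is expected in this assay, in either direction. The estimated step is a 1.2-fold lower number from compound 1 to compound 3 (0.07 log units; within the scatter). The expected value for compound 3 is 400 nM, with an estimated range of 150 nM to 1000 nM.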

Compound 3, half-maximal inhibitory concentration: 47 nM
Compound 3: middle estimate off by 8.5-fold (0.93 log units), on the high side; measured number below the stated range.
By their numbers in this assay, from the lowest: compound 3; then compounds 2 and 1 (each within the scatter of the next).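

In this assay, fluoro in place of hydrogen on an aromatic carbon, meta to a fused ring and para to a fused ring, gives a 10-fold lower number from compound 1 to compound 3 (1.00 log units; beyond the scatter), the only step shown that lies beyond the scatter. The methoxy change, by contrast, gives a 1.8-fold lower number from compound 1 to compound 2 (0.26 log units; within the scatter), so the earlier pair gave no sign that a single substituent on this ring of the shared core could shift the number this far. Nothing available here explains the size of the fluoro step.

Compound 2 and compound 3 differ in more than one place, so the role of the group cannot be separated from that of the carbon it occupies. From the compounds shown here alone, whether the effect is specific to fluoro remains open, as chloro, methoxy or an amine on this same carbon would be needed to tell.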